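The compounds below may be only part of what the source reports. "The series", "measured", "known", "first", "only" and "open" are said of these compounds alone.

In a functional assay on COLO 205 cells (Homo sapiens) for inhibition, read by sulforhodamine B assay, tested at 10 uM (on this read-out lower numbers stand for less inhibition of growth and higher numbers for more inhibition of growth at the one concentration tested), the three measured compounds gave these numbers:

Compound 1 `COc1cc(C2CC(c3ccc([N+](=O)[O-])cc3)=NN2C(C)=O)ccc1OCc1cn(Cc2ccc([N+](=O)[O-])cc2)nn1`: 33%
Compound 2 `COc1cc(C2CC(c3ccc(Br)cc3)=NN2C(C)=O)ccc1OCc1cn(Cc2ccc([N+](=O)[O-])cc2)nn1`: 26%
Compound 3 `COc1ccc(C2=NN(C(C)=O)C(c3ccc(OCc4cn(Cc5ccc([N+](=O)[O-])cc5)nn4)c(OC)c3)C2)cc1`: 10%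

Compound 3 stands lowest of the three: a number 23 percentage points lower from compound 1 to compound 3 (beyond the scatter) and a number 16 percentage points lower from compound 2 to compound 3 (beyond the scatter) are both beyond the scatter, while compound 1 and compound 2 sit within the scatter of each other.

Compound 4 `COc1cc(C2CC(c3cccc4ccccc34)=NN2C(C)=O)ccc1OCc1cn(Cc2ccc([N+](=O)[O-])cc2)nn1` differs from compound 3 by naphthalen-1-yl in place of 4-methoxyphenyl on a carbon with a double bond to nitrogen. For the measured compounds named here, the steps that bear on this change are the two in which a new group entered at this same position: a number 23 percentage points lower from compound 1 to compound 3 (beyond the scatter) and a number 16 percentage points lower from compound 2 to compound 3 (beyond the scatter). Going by the values given here, both moved the number down modestly when methoxy arrived, so removing the methoxyphenyl again is expected to move it back up, though naphthalen-1-yl itself appears in no measured pair. Compound 4 is therefore estimated at 25%, with a range from 8% to 45%, meaning an expected a number 15 percentage points higher from compound 3 to compound 4 (beyond the scatter).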

Compound 4, percent growth inhibition at one concentration: 46%
Compound 4: the middle estimate sits 21 percentage points below what was measured, and the stated range ends below it.
By their numbers in this assay, from the lowest: compound 3; then compounds 2 and 1 (each within the scatter of the next); then compound 4.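

With naphthalen-1-yl on the carbon with a double bond to nitrogen, compound 4 stands highest of the four in this assay, with a number 36 percentage points higher from compound 3 to compound 4 (beyond the scatter) and a number 20 percentage points higher from compound 2 to compound 4 (beyond the scatter) and also a number 13 percentage points higher from compound 1 to compound 4 (beyond the scatter) as its steps. This position therefore accepts two aromatic rings in place of a substituted phenyl ring, with more inhibition of growth. No available evidence explains this gain.

Going by these compounds, whether the gain depends on the second ring or on how it is joined stays open; naphthalen-2-yl, plain phenyl or cyclohexyl would help separate these.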